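The source may report more compounds than this note shows. Statements on the series, on what has been measured and on what is new or still open speak of the compounds shown alone.

Measured so far in a functional assay on SK-BR-3 cells (Homo sapiens) for antiproliferative activity, with a stated time of 72 h; on this read-out lower numbers stand for stronger inhibition of growth and higher numbers for weaker inhibition of growth:
Compound 1 `COc1cc(CN(C)C(=O)c2cc(Cl)c(O)cc2O)cc(OC)c1OC` gives 30100 nM.
Compound 2 `COc1cc(CN(C)C(=O)c2cc(Cl)c(O)cc2O)c(Br)c(OC)c1OC` gives 7700 nM.
Compound 3 `COc1ccc(CN(C)C(=O)c2cc(Cl)c(O)cc2O)cc1` gives 7200 nM.

Compound 3 has the lowest of the three numbers, but its gap to compound 2 is within the scatter, so those two cannot be ranked against each other; only compound 1 stands clearly apart. Compound 4 `CN(Cc1ccccc1)C(=O)c1cc(Cl)c(O)cc1O` differs from compound 3 by hydrogen in place of methoxy on an aromatic carbon. Within the data shown here, the only measured single-change step, a 3.9-fold lower number from compound 1 to compound 2 (0.59 log units; beyond the scatter), concerns a different group at a different place and gives no direct guide. Among the measured compounds shown here, compounds 1 and 3 differ at two places, so their values show only that the compound with fewer methoxy groups had the lower number. For the measured compounds named here, no measured step removes one methoxy alone. The expectation for compound 4 in this assay is therefore a step of a 1.3-fold higher number from compound 3 to compound 4 (0.10 log units; within the scatter), no larger than the scatter, with an estimate of 9000 nM and a range from 3000 nM to 30000 nM.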

Compound 4, concentration for 50% growth inhibition: 18300 nM
For compound 4 the middle estimate is 2.0-fold (0.31 log units) below the measured one; measured number inside the range.
By their numbers in this assay, from the lowest: compounds 3 and 2 (each within the scatter of the next); then compounds 4 and 1 (each within the scatter of the next).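

In this assay, among these compounds, the step of a 2.5-fold higher number from compound 3 to compound 4 (0.41 log units; beyond the scatter) is the first measured change made at this position alone. On this aromatic carbon, para to a large group, the compound with methoxy gives the lower number and the compound with hydrogen the higher, so in this pair the group present there matters. Nothing measured here explains the shift. As far as these compounds go, whether an amine or a longer chain such as ethoxy on this carbon would lower or raise the number remains open. So does whether losing this methoxy would have the same effect alongside the other groups in compounds 1 and 2.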